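A few compounds are considered here, and "the series" means these few. Any claim that something is new, unique, unknown or untested is made for them only; others in the source may bear on it.

Working notes on the series. The shared core of compound 1 `Clc1cncc(N2CCCNCCC2)c1` is a pyridine-type ring carrying an eight-membered diamine; in a functional assay on HEK293 cells for agonist activity at Neuronal acetylcholine receptor; alpha4/beta2 (Homo sapiens), read by FLIPR and calcium flux (a lower number here means that less compound is needed, a higher number that more compound is needed for the effect), compound 1 gives 170 nM, the lowest of the three numbers in hand. Nearest to it stands compound 3 `Oc1cc(N2CCCNCC2)cnc1I`, which in this assay gives 479 nM, a gap beyond the scatter. Furthest away is compound 2 `C=COc1cncc(N2CCNCC2)c1`, which in this assay gives 7590 nM, far beyond the scatter. No two of these measured compounds differ in only one place, so none of those gaps can be read as a single step.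

The next compound, compound 4 `COc1cncc(N2CCCNCCC2)c1`, differs from compound 1 in one place: methoxy in place of chloro on an aromatic carbon. Within the data shown here, no measured pair shows the effect of this exchange on this core. Among the measured compounds shown here, compound 2, the only other member carrying an oxygen-linked substituent on the ring, sits highest, but its ring amine also differs, so it offers no clean guide. The expectation is a moderate loss, with the step from compound 1 to compound 4 estimated at a 2.4-fold higher number from compound 1 to compound 4 (0.37 log units; beyond the scatter). For compound 4 in this assay the estimated value is 400 nM, expected to lie between 120 nM and 1500 nM.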

Compound 4, half-maximal effective concentration: 120 nM
Compound 4: middle estimate off by 3.3-fold (0.52 log units), on the high side; low and high end bracket the measured number.
By their numbers in this assay, from the lowest: compounds 4 and 1 (each within the scatter of the next); then compound 3; then compound 2.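

On this core, the aromatic carbon two atoms from the ring nitrogen accepts methoxy in place of chloro in this assay with no clear change: the exchange gives a 1.4-fold lower number from compound 1 to compound 4 (0.15 log units; within the scatter), even though methoxy has 2 heavy atoms and 1 hydrogen-bond acceptor while chloro has 1 heavy atom and 0 hydrogen-bond acceptors. Among these compounds, this is the first step that can be read as a single change, and it shows that an oxygen-linked substituent at this position does not by itself bring a high number on this core, as compound 4 gives 120 nM. Nothing in hand explains why the two groups cannot be told apart here.

As far as these compounds go, whether this holds for groups of another kind at the same position, such as an amine, a carboxylic acid or a longer alkoxy chain, remains open. Also open, from the compounds shown here alone, is whether the exchange of chloro for methoxy would read the same with the other ring amines in compound 2 and compound 3, as neither compound forms a single-place pair with compound 1 or compound 4.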